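The source may report more compounds than this note shows. Statements on the series, on what has been measured and on what is new or still open speak of the compounds shown alone.

Working notes on the series, read in an ADME assay on HEK293 cells (Homo sapiens) for cytotoxicity, read by MTT assay, with a stated time of 72 h; on this read-out lower numbers stand for stronger inhibition and higher numbers for weaker inhibition. Compound 1 `COc1ccc(OC)c(C2=C(c3cc(OC)c(OC)c(OC)c3)C(=O)CC2O[SiH2]C(C)(C)C)c1` gives 9.5 ug/mL. Compound 2 `COC(=O)c1cc(C2=C(c3cc(OC)c(OC)c(OC)c3)C(=O)CC2O[SiH2]C(C)(C)C)ccc1OC` reads > 100 ug/mL, which is a limit and not a number. Compound 3 `COCOc1cc(C2=C(c3cc(OC)c(OC)c(OC)c3)C(=O)CC2O[SiH2]C(C)(C)C)ccc1OC` reads > 100 ug/mL, again a limit and not a number. Compound 3 therefore sits at the limit of > 100 ug/mL in this assay, at which 2 of the 3 values shown sit.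

Two measured steps end at a limit, and both are large and beyond the scatter: an at least 10-fold higher number from compound 1 to compound 2 (1.02 log units; beyond the scatter), and an at least 10-fold higher number from compound 1 to compound 3 (1.02 log units; beyond the scatter). The remaining comparison gives no size: a step that the two limits leave unreadable from compound 2 to compound 3.

Compound 4 `COc1ccc(C2=C(c3cc(OC)c(OC)c(OC)c3)C(=O)CC2O[SiH2]C(C)(C)C)cc1O` differs from compound 3 as follows: hydrogen in place of methoxymethyl on an oxygen on an aromatic ring. This is hydrogen in place of methoxymethyl on an oxygen on an aromatic ring, turning methoxymethoxy to hydroxy and 4-methoxy-3-(methoxymethoxy)phenyl to 3-hydroxy-4-methoxyphenyl.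

Among the compounds with values here, no measured step covers this exchange directly. The closest guide is compound 1 at 9.5 ug/mL, which shows that a change of the group on the double-bonded ring carbon can give a readable number in this series. A moderate move toward a lower number is expected, and a reading at the limit remains quite possible. The expected step is an at least 1.6-fold lower number from compound 3 to compound 4 (0.22 log units; that floor lies within the scatter). For compound 4 the estimate is 60 ug/mL, with an expected range of 12 ug/mL to 150 ug/mL.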

Compound 4, half-maximal inhibitory concentration: 42 ug/mL
Compound 4: middle estimate off by 1.4-fold (0.15 log units), on the high side; low and high end bracket the measured number.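

In this assay, within the data shown here, hydrogen in place of methoxymethyl on the oxygen on the aromatic ring gives the first readable number among the compounds with a single oxygen-bearing change at this place, with an at least 2.3-fold lower number from compound 3 to compound 4 (0.37 log units; beyond the scatter). Hydroxy in place of methoxycarbonyl on the aromatic carbon also moves the read-out off the limit, with an at least 2.3-fold lower number from compound 2 to compound 4 (0.37 log units; beyond the scatter), so a free hydroxy at this place separates compound 4 from compound 2 and compound 3. The 3-hydroxy-4-methoxyphenyl group still does not reach the level of the 2,5-dimethoxyphenyl group on the double-bonded ring carbon, with a 4.4-fold higher number from compound 1 to compound 4 (0.65 log units; beyond the scatter).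

On these data alone, compound 2 and compound 3 each stay a limit and not a number, so the first two steps give only floors and the step between compound 2 and compound 3 cannot be read: the limit of > 100 ug/mL in this assay, at which 2 of the 4 values shown sit. Still open is how an amine or a carboxylic acid at this place would read, and whether a longer chain such as ethyl or propyl on the oxygen would stay at the limit or give a readable number.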